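The compounds below may be only part of what the source reports. "The series", "measured", "known", "first", "only" and "open" are said of these compounds alone.

Compound 1 `C=CS(=O)(=O)NCc1ccc(C(=O)Nc2ccc(C)c(Nc3nccc(-c4cccnc4)n3)c2)cc1` in an ADME assay on BaF3 cells (Mus musculus) for cytotoxicity, read by CellTiter-Glo and CCK-8 assay, with a stated time of 72 h (on this read-out lower numbers stand for stronger inhibition of growth and higher numbers for weaker inhibition of growth), gives 7710 nM. Compound 2 `C=CC(=O)N(CCN(C)C)Cc1ccc(C(=O)Nc2ccc(C)c(Nc3nccc(-c4cccnc4)n3)c2)cc1` reaches only the limit of this assay, > 10000 nM, which is a limit and not a number, as recorded in the limit of > 10000 nM in this assay, at which 1 of the 2 values shown sits. Among the compounds with values here, the single measured step, an at least 1.2-fold higher number from compound 1 to compound 2 (0.11 log units; that floor lies within the scatter), sits at a floor inside the scatter. Compound 3 `Cc1ccc(NC(=O)c2ccc(CN(CCN(C)C)C(=O)c3cccs3)cc2)cc1Nc1nccc(-c2cccnc2)n1` differs from compound 2 by thiophen-2-yl in place of vinyl on a carbonyl carbon. Within the data shown here, no measured step touches a change on this carbonyl carbon, so the series gives no direction for it, and compound 2 already stands at the limit. Compound 3 is expected at 15000 nM, range 7000 nM to 40000 nM. The estimated step that the limit leaves unreadable from compound 2 to compound 3 is expected to stay within the scatter.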

Compound 3, concentration for 50% growth inhibition: > 10000 nM
Compound 3 gave a limit, no number (the forecaster's own chance of this, stated with the estimate: 70%); the middle value does not contradict the limit.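

No step can be read from compound 2 to compound 3, because both values are limits and not numbers: the limit of > 10000 nM in this assay, at which 2 of the 3 values shown sit.

The compounds shown leave open how thiophen-2-yl compares with vinyl on this carbonyl carbon.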